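The source may hold more compounds than are shown below. What is called first, only, known or untested is meant among the compounds shown, and "the series" means these compounds.

Three compounds in this set share one core and differ in the groups hung from it. Compound 1 `CC(O)CNc1nc(-c2ccccc2)nc2c1nnn2Cc1ccccc1Cl` gives 32000000 nM in an assay on isolated protein for binding affinity to adenosine receptor A1 (Bos taurus) (a lower number here means a stronger inhibitor, a higher number a weaker inhibitor), the highest of the three numbers, so it is the weakest binder here. Compound 2 `CC(O)CNc1nc(-c2ccccc2)nc2c1nnn2Cc1ccccc1F` gives 4800000 nM, and compound 3 `OC1CCC(Nc2nc(-c3ccccc3)nc3c2nnn3Cc2ccccc2)CC1` gives 2700000 nM, both well below compound 1.

Within the data shown here, the one measured step, a 6.7-fold lower number from compound 1 to compound 2 (0.82 log units; beyond the scatter), comes from swapping a halogen on the benzyl ring. Compound 3 carries a different group on the exocyclic nitrogen and lacks the halogen altogether, so its lower number cannot be tied to a single change.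

Compound 4 `COc1ccc(C(=O)Nc2nc(-c3ccccc3)nc3c2nnn3Cc2ccccc2Cl)cc1` keeps the chlorinated benzyl group of compound 1 and alters the other side: (4-methoxyphenyl)carbonyl in place of 2-hydroxypropyl on a nitrogen on an aromatic ring. Among the measured compounds shown here, no measured pair isolates a change at this nitrogen, so the halogen step offers no guide to its size or direction. All three known values sit at the very weak end of this assay, so the estimate for compound 4 is placed near compound 1 with a wide range and no clear direction: the expected step is a 2.1-fold lower number from compound 1 to compound 4 (0.33 log units; beyond the scatter), and the expected value for compound 4 is 15000000 nM, between 1500000 nM and 150000000 nM.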

Compound 4, inhibition constant: 20000000 nM
Beside the measured number, compound 4's estimate is 1.3-fold (0.12 log units) below it; the range from low to high includes it.
By their numbers in this assay, from the lowest: compounds 3 and 2 (each within the scatter of the next); then compounds 4 and 1 (each within the scatter of the next).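

In this assay the exchange at this nitrogen gives a 1.6-fold lower number from compound 1 to compound 4 (0.20 log units; within the scatter) even though the entering (4-methoxyphenyl)carbonyl group is much larger than 2-hydroxypropyl, brings a six-membered aromatic ring and a carbonyl, and has no hydrogen-bond donor where the leaving group has one. This nitrogen had not been probed by any earlier pair, and here a large change of group leaves no readable shift in the number, whereas a 6.7-fold lower number from compound 1 to compound 2 (0.82 log units; beyond the scatter) came with the halogen swap on the benzyl ring and lies beyond the scatter. Nothing measured in this set accounts for this result.

Because the carbonyl, the aromatic ring and the methoxy group all enter together, the compounds shown cannot separate what each part contributes, and a plain benzoyl group or a benzyl group on the same nitrogen would bear on that. Going by these compounds, it also remains open whether any group at this nitrogen, such as a small methyl, a longer alkyl chain or a chain ending in a carboxylic acid, would lift the number out of the very weak range where compound 1 and compound 4 both sit.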